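From 4-fluorobenzyl to isopropyl on a shared core

The compounds below may be only part of what the source reports. "The series", "measured", "known", "first", "only" and "open" are said of these compounds alone.

Among the compounds with values here, in an ADME assay on A549 cells (Homo sapiens) for cytotoxicity, read by LDH release, with a stated time of 15 h (on this read-out lower numbers stand for higher toxicity in this test and higher numbers for lower toxicity in this test), compound 1 `O=C(Nc1ccc(NCC2CCCC2)cc1Cl)c1cc(Cl)ccc1O` gives 141000 nM and this remains the only number available so far. Compound 2 `O=C(Nc1ccc(NCc2ccc(F)cc2)cc1Cl)c1cc(Cl)ccc1O` shares the core of compound 1 but has no place on this scale: the entry for compound 2 reads "not determined" (no result reported) and no result was reported.

Compound 3 `CC(C)Nc1ccc(NC(=O)c2cc(Cl)ccc2O)c(Cl)c1` differs from compound 2 in one place, with isopropyl in place of 4-fluorobenzyl on a nitrogen on an aromatic ring as the whole of the change. Within the data shown here, with no number for compound 2, the size of this step in this assay cannot be read from the data, and no step between measured compounds is available as a guide. Among the measured compounds shown here, the only reference is compound 1 at 141000 nM so compound 3 is expected to fall near that level, with no shift beyond the usual scatter in either direction. Compound 3 is therefore expected at 120000 nM within an estimated range from 40000 nM to 350000 nM once it is measured.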

Compound 3, half-maximal cytotoxic concentration: 82700 nM
Estimate against measurement, compound 3: 1.5-fold (0.16 log units) above; low and high end bracket the measured number.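

In this assay, the substituent on a nitrogen on an aromatic ring now has one readable step: isopropyl in place of cyclopentylmethyl gives a 1.7-fold lower number from compound 1 to compound 3 (0.23 log units; within the scatter), so this test does not separate the two groups on the shared core, even though isopropyl has no ring. Compound 2 has no number, so the step from 4-fluorobenzyl to isopropyl cannot be read, and the data say nothing about the aromatic ring that 4-fluorobenzyl carries. Nothing available explains why these two groups fall within the scatter of each other.

The compounds shown leave open whether a substituent on this nitrogen carrying an amine or a carboxylic acid, or a longer chain such as n-hexyl, would take the number in this assay beyond the scatter of this level. Also open, going by these compounds, is whether a benzyl group without the fluorine, or any other group with an aromatic ring at this place, would sit at the same level as the two groups that can be compared here.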